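The source may hold more compounds than are shown below. What is called first, only, known or untested is meant among the compounds shown, and "the series" means these compounds.

Values measured so far in a functional assay on Bel-7402 cells (Homo sapiens) for cytotoxicity, read by resazurin assay, with a stated time of 72 h; a lower number here means a stronger inhibitor, a higher number a weaker inhibitor:
- compound 1 (`N#CCCSC(=S)NCc1cccnc1`): 1030 nM
- compound 2 (`Cc1nc(-c2ccccc2)oc1CNC(=S)SCCC#N`): 18000 nM

Compound 1 holds the lower of the two numbers, and compound 2 sits above it by more than the scatter. These two compounds differ in more than one place, so they give no direct measure of any single change.

The next step leads to compound 3 (`O=C(O)CCSC(=S)NCc1cccnc1`), which has carboxy in place of cyano on a saturated chain carbon, two bonds along the chain from a sulfur. Going by the values given here, no measured pair covers this change, so the expectation is loose. A higher number in this assay is expected. The expected step is a 12-fold higher number from compound 1 to compound 3 (1.07 log units; beyond the scatter) and points to a weaker inhibitor, beyond the scatter. Compound 3 is estimated at 12000 nM with an expected range from 2500 nM to 60000 nM in this read-out.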

Compound 3, half-maximal inhibitory concentration: 7420 nM
For compound 3 the middle estimate is 1.6-fold (0.21 log units) above the measured one, and the stated range covers the measured number.
By their numbers in this assay, from the lowest: compound 1; then compound 3; then compound 2.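

In this assay, going by these compounds alone, the change from 2-cyanoethyl to 2-carboxyethyl gives the first single-change reading: a 7.2-fold higher number from compound 1 to compound 3 (0.86 log units; beyond the scatter), so the group at this chain end affects the read-out, and carboxy gives the weaker inhibitor. Compound 3 still gives a measured number of 7420 nM, so carboxy on a saturated chain carbon, two bonds along the chain from a sulfur, weakens the response without abolishing it. Nothing measured here accounts for the size of this step.

As far as these compounds go, it remains open whether the step is particular to carboxy, or whether a methyl ester, a primary amide or an amine at the same chain end would read similarly. From the compounds shown here alone, how a longer chain would read, and whether the same change carries over to the core of compound 2, also stays open.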